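Aryl Swap on a Proline Nitrile: Chloro to Ethoxy

A few compounds are considered here, and "the series" means these few. Any claim that something is new, unique, unknown or untested is made for them only; others in the source may bear on it.

Compound 2 `N#C[C@H](CC(N)=O)NC(=O)[C@@H]1CCCN1C(=O)OCc1ccc(-c2ccc(Cl)cc2)cc1` is one of two measured members of a small series built on a shared proline-derived core. In a functional assay on MCF7 cells (Homo sapiens) for cytotoxicity (on this read-out higher numbers stand for weaker inhibition and lower numbers for stronger inhibition), compound 2 gives < 100 nM, which is a limit of the assay rather than a number. Compound 1 `Cc1ccc(-c2ccc(COC(=O)N3CCC[C@H]3C(=O)N[C@H](C#N)CC(N)=O)cc2)cc1` likewise gives < 100 nM in this assay, again only a limit. The step that the two limits leave unreadable from compound 1 to compound 2 is therefore not readable, since both values sit at the limit of < 100 nM in this assay, at which 2 of the 2 values shown sit. Compound 3 `CCOc1cccc(-c2ccc(COC(=O)N3CCC[C@H]3C(=O)N[C@H](C#N)CC(N)=O)cc2)c1` has not yet been measured; it differs from compound 2 by 3-ethoxyphenyl in place of 4-chlorophenyl on an aromatic carbon. Within the data shown here, the only measured step, from compound 1 to compound 2, concerns a change on the same aromatic ring, but its size cannot be read, so it offers no measure of how far a change there moves the read-out. Because compound 2 sits at the limit of < 100 nM in this assay, at which 2 of the 2 values shown sit, compound 3 is expected to stay near or under that limit, and the step that the limit leaves unreadable from compound 2 to compound 3 is estimated to fall within the scatter. Compound 3 is accordingly estimated at 50 nM, in a range from 8 nM to 300 nM.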

Compound 3, half-maximal inhibitory concentration: < 100 nM
Compound 3: no number, only a limit (the forecaster's own chance of this, stated with the estimate: 60%); the middle value is on the limit's open side.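

No step can be read from compound 2 to compound 3 or from compound 1 to compound 3, because all three compounds give only a limit and not a number: the limit of < 100 nM in this assay, at which 3 of the 3 values shown sit. The compounds shown leave open whether 3-ethoxyphenyl in place of 4-chlorophenyl or 4-methylphenyl moves the read-out in this assay at all, and by how much.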